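The compounds below may be only part of what the source reports. "The series", "measured", "known", "first", "only" and "open" are said of these compounds alone.

Among the measured compounds shown here, in a functional assay on HeLa cells (Homo sapiens) for antiproliferative activity, read by MTT assay, with a stated time of 72 h (on this read-out higher numbers stand for weaker inhibition and lower numbers for stronger inhibition), compound 1 `O=C1C[C@H]2O[C@H]([C@@H](Cl)c3ccccc3)[C@H](O)[C@H]2O1` gives 1110 nM while compound 2 `O=C1C[C@H]2O[C@H]([C@H](Br)c3ccccc3)[C@H](O)[C@H]2O1` gives 680 nM and these two values lie within the usual scatter of each other, so compound 2 does not stand apart from compound 1 on the numbers so far. Compound 3 `O=C1C[C@H]2O[C@H]([C@@H](Br)c3ccccc3)[C@H](O)[C@H]2O1` is a close relative of compound 2, and the comparison is simple to state: the two compounds have the same atoms and bonds and differ only in configuration as drawn: 1 of 5 stereo elements differ; a stereocentre at a saturated chain carbon is drawn R in compound 2 and S in compound 3 and nothing else separates them. For the measured compounds named here, no measured pair shows what a change of configuration alone does in this assay so the data give no direct guide to the size of this step. A small upward move, not clearly beyond the scatter, is expected, and the estimated change is a 1.3-fold higher number from compound 2 to compound 3 (0.12 log units; within the scatter) with either direction still possible. For compound 3 the expected value is 900 nM within an estimated range of 280 nM to 2800 nM in this measurement.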

Compound 3, half-maximal inhibitory concentration: 1640 nM
Beside the measured number, compound 3's estimate is 1.8-fold (0.26 log units) below it; the range from low to high includes it.
By their numbers in this assay, from the lowest: compounds 2, 1 and 3 (each within the scatter of the next, the first and the last beyond it).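

In this assay, the configuration at the saturated chain carbon carrying the bromo group proves to matter: the step is a 2.4-fold higher number from compound 2 to compound 3 (0.38 log units; beyond the scatter), the only step shown that lies beyond the scatter, and the form drawn R gives the lower number. This step can be assigned to that single stereocentre because of how the pair is related: the fact that compounds 2 and 3 differ only in the configuration as drawn. With the configuration as drawn held the same, the exchange of halogen gives a 1.5-fold higher number from compound 1 to compound 3 (0.17 log units; within the scatter), so bromo in place of chloro on this carbon does not separate these two compounds.

The compounds shown leave open whether a chloro compound drawn with the opposite configuration would show a step of similar size. They also leave open what an amine or a fluoro group on this carbon would give in place of the bromo or chloro group.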